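Methylsulfonyl for Methyl: Cytotoxicity Expected to Stay Low

This account rests on a few compounds, and the source may have more. Where it says the series, first, only, none or still open, it means among the compounds named here.

Measured so far:
In an ADME assay on NIH3T3 cells (Mus musculus) for cytotoxicity, read by CCK-8 assay, with a stated time of 24 h (on this read-out higher numbers stand for weaker inhibition and lower numbers for stronger inhibition), compound 1 `C/C(=C\c1cc(-c2cccnc2)co1)C(N)=O` gives > 50000 nM, a limit of the assay rather than a number.
In this assay compound 2 `C/C(=C\c1cc(-c2ccc(C)cc2)cs1)C(N)=O` gives > 50000 nM, again a limit and not a number.

Compound 2 thus stands at the limit of > 50000 nM in this assay, at which 2 of the 2 values shown sit, so no value in this assay has yet been resolved to a number. Compound 3 `C/C(=C\c1cc(-c2ccc(S(C)(=O)=O)cc2)cs1)C(N)=O` differs from compound 2 in one place: methylsulfonyl in place of methyl on an aromatic carbon. Going by the values given here, no measured step of this kind exists here. For compound 3 the expected step that the limit leaves unreadable from compound 2 to compound 3 is none beyond the scatter, most likely ending again at a limit. Compound 3 is therefore estimated at 60000 nM, within 30000 nM to 150000 nM.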

Compound 3, half-maximal inhibitory concentration: > 50000 nM
Compound 3 ended at the assay's limit (the forecaster's own chance of this, stated with the estimate: 85%); the middle value is on the limit's open side.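

Going by these compounds alone, compound 2 and compound 3 both end at a limit of the assay rather than at a number, so no step between them can be read: the limit of > 50000 nM in this assay, at which 3 of the 3 values shown sit.

The compounds shown leave open how strongly any of them acts in this assay and whether methylsulfonyl in place of methyl on an aromatic carbon changes that at all.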